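This account rests on a few compounds, and the source may have more. Where it says the series, first, only, none or still open, it means among the compounds named here.

Going by the values given here, in a physicochemical assay for lipophilicity, at pH 7.4 (a lower number here means a more polar compound, a higher number a more lipophilic compound), compound 2, `COC(=O)c1cc(N)c(Nc2ccc(C#N)cc2)cc1Oc1c(C)cc(/C=C/C#N)cc1C`, gives 4.15, the only exact number so far. Compound 1, `Cc1cc(/C=C/C#N)cc(C)c1Oc1cc(Nc2ccc(C#N)cc2)c(N)cc1[N+](=O)[O-]`, reads > 5, which is a limit of the assay and not a number. Methoxycarbonyl in place of nitro on an aromatic carbon gave a number at least 0.85 log units lower from compound 1 to compound 2 (beyond the scatter). Among the compounds with values here, that is the only measured step, and its true size stays open, as it rests on (the limit of > 5 in this assay, at which 1 of the 2 values shown sits). It also involves a different swap, so it is a loose guide at best. Compound 3, `Cc1cc(/C=C/C#N)cc(C)c1Oc1cc(Nc2ccc(C#N)cc2)c(N)cc1CO`, carries hydroxymethyl in place of methoxycarbonyl on an aromatic carbon. The entering group is smaller and brings a hydrogen-bond donor. Starting from compound 2 at 4.15, a modest fall beyond the scatter is expected, a number 0.55 log units lower from compound 2 to compound 3 (beyond the scatter). For compound 3 the estimated value is 3.6, with an expected range from 3 to 4.2.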

Compound 3, partition coefficient: 4.14
Beside the measured number, compound 3's estimate is 0.54 log units below it; the range from low to high includes it.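

In this assay, hydroxymethyl and methoxycarbonyl on this aromatic carbon cannot be told apart, even though hydroxymethyl has fewer heavy atoms and brings a hydrogen-bond donor: the step is a number 0.01 log units lower from compound 2 to compound 3 (within the scatter). Replacing nitro with hydroxymethyl gives a number at least 0.86 log units lower from compound 1 to compound 3 (beyond the scatter), so two different replacements for nitro now both read clearly lower than compound 1. As far as these compounds go, the true size of this step stays open, because one end of it is not an exact number: the limit of > 5 in this assay, at which 1 of the 3 values shown sits.

From the compounds shown here alone, whether a carboxylic acid, an amide or an amine at this position would also read like compound 2 and compound 3 remains open. The compounds shown also cannot tell whether a longer chain ending in a hydroxyl group would match hydroxymethyl here.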